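Compound 4 as a difluoro change from compound 3

This account rests on a few compounds, and the source may have more. Where it says the series, first, only, none or still open, it means among the compounds named here.

In a functional assay (QGY7701 cells, Homo sapiens) for inhibition, read by MTT assay, with a stated time of 48 h (on this read-out higher numbers stand for weaker inhibition and lower numbers for stronger inhibition), compound 1 (`COc1ccc(CNC(=O)/C=C/c2coc3cc(O)ccc3c2=O)cc1`) gives 10000 nM, compound 2 (`O=C(/C=C/c1coc2cc(O)ccc2c1=O)NCc1ccccc1`) gives 63000 nM and compound 3 (`Cc1ccc(CNC(=O)/C=C/c2coc3cc(O)ccc3c2=O)cc1`) gives 24900 nM. Compound 3 therefore holds the middle of the three numbers. Compound 4 (`O=C(/C=C/c1coc2cc(O)ccc2c1=O)NCc1ccc(F)cc1F`) has 2,4-difluorophenyl in place of 4-methylphenyl on a saturated chain carbon bound to an amide-type nitrogen. Among the compounds with values here, no fluorine-bearing compound has been measured, so only the modest aromatic-carbon steps bear on this change: a 2.5-fold lower number from compound 2 to compound 3 (0.40 log units; beyond the scatter), a 2.5-fold higher number from compound 1 to compound 3 (0.40 log units; beyond the scatter) and a 6.3-fold higher number from compound 1 to compound 2 (0.80 log units; beyond the scatter). They give no direction for fluorine. The expected change is a 1.2-fold higher number from compound 3 to compound 4 (0.08 log units; within the scatter), with no step beyond the scatter anticipated. For compound 4 the estimated value is 30000 nM, with an expected range of 11000 nM to 80000 nM.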

Compound 4, half-maximal inhibitory concentration: > 100000 nM
Compound 4: no number, only a limit; the forecaster's own chance of this, stated with the estimate: 10%; middle value at least 3.3-fold (0.52 log units) from the limit.
By their numbers in this assay, from the lowest: compound 1; then compound 3; then compound 2. At a limit, above all of these: compound 4.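

In this assay the reading for compound 4 is a limit, not a number: the limit of > 100000 nM in this assay, at which 1 of the 4 values shown sits. At this position, 2,4-difluorophenyl gives an at least 4.0-fold higher number from compound 3 to compound 4 (0.60 log units; beyond the scatter) and an at least 10-fold higher number from compound 1 to compound 4 (1.00 log units; beyond the scatter), so a ring substituent here does not always lower the number, as methyl and methoxy did. Against plain phenyl the result is an at least 1.5-fold higher number from compound 2 to compound 4 (0.20 log units; that floor lies within the scatter), and that floor does not separate the two.

Open, on these data alone, is whether one fluorine alone, or the pair, accounts for the loss. A chlorine or a dimethylamino group on the phenyl ring would test how far the methoxy and methyl trend extends.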